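Compound 3 and the shift to a 2-methoxyphenyl group

This account rests on a few compounds, and the source may have more. Where it says the series, first, only, none or still open, it means among the compounds named here.

Compound 2 `Cc1nn(-c2nc(-c3ccc(Cl)c(Cl)c3)c(SC(C)C)s2)c(C(=O)O)c1-c1cccc(C(F)(F)F)c1` was tested in a functional assay on BJAB cells (Homo sapiens) for antiproliferative activity, with a stated time of 4 days (on this read-out higher numbers stand for an effect only at larger amounts of compound and lower numbers for an effect already at smaller amounts), where compound 2 gives 22000 nM. For the measured compounds named here, that is the highest of the two numbers measured so far; its nearest neighbour is compound 1 `Cc1ccc(-c2c(C)nn(-c3nc(-c4ccc(Cl)c(Cl)c4)c(SC(C)C)s3)c2C(=O)O)cc1`, which in this assay gives 3800 nM. Going by the values given here, the only measured step is a 5.8-fold higher number from compound 1 to compound 2 (0.76 log units; beyond the scatter), and it changed a single aryl group on the shared core. Compound 3 `COc1ccccc1-c1c(C)nn(-c2nc(-c3ccc(Cl)c(Cl)c3)c(SC(C)C)s2)c1C(=O)O` has not yet been measured in this assay. It differs from compound 2 in one place: 2-methoxyphenyl in place of 3-(trifluoromethyl)phenyl on an aromatic carbon. Among the compounds with values here, no measured step covers a 2-methoxyphenyl group at that position, so the sole guide is that the one aryl exchange measured, from compound 1 to compound 2, moved the number by a modest amount, and that the 3-(trifluoromethyl)phenyl group of compound 2 now leaves. Compound 3 is therefore expected to give a number in this assay that lies somewhere between those of its two relatives, and the estimated step is a 2.8-fold lower number from compound 2 to compound 3 (0.44 log units; beyond the scatter). For compound 3 the estimate is 8000 nM, with a range from 2500 nM to 25000 nM.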

Compound 3, half-maximal effective concentration: 14700 nM
The estimate for compound 3 lay 1.8-fold (0.26 log units) below the measured number; the range from low to high includes it.
By their numbers in this assay, from the lowest: compound 1; then compounds 3 and 2 (each within the scatter of the next).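

In this assay, putting 2-methoxyphenyl in place of 3-(trifluoromethyl)phenyl gives a 1.5-fold lower number from compound 2 to compound 3 (0.18 log units; within the scatter), so at this position these two aryl groups cannot be told apart, even though 2-methoxyphenyl brings one hydrogen-bond acceptor and 3-(trifluoromethyl)phenyl brings none. Measured against 4-methylphenyl, the same 2-methoxyphenyl group gives a 3.9-fold higher number from compound 1 to compound 3 (0.59 log units; beyond the scatter), which makes 4-methylphenyl the only one of the three aryl groups that stands apart, with the lowest number, while the other two lie together within the scatter. Nothing available on these compounds accounts for why 4-methylphenyl stands apart in this way.

The compounds shown leave open whether a plain phenyl, a phenyl ring carrying an amine, or a saturated ring such as cyclohexyl at this position would fall nearer to compound 1 or nearer to compound 2 and compound 3. They also leave open whether the same standing of the three aryl groups would hold if the carboxy group on the shared core gave way to an amide.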